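A few compounds are considered here, and "the series" means these few. Any claim that something is new, unique, unknown or untested is made for them only; others in the source may bear on it.

Of the compounds shown here, three have been measured in an assay on membranes from brain for displacement of a labelled ligand from Sigma non-opioid intracellular receptor 1 (Cavia porcellus), read by scintillation counting, with a stated time of 120 min; a lower number here means a stronger inhibitor, a higher number a weaker inhibitor. Compound 1, with the structure `CCN(CCCc1ccccc1)C1CCc2ccsc2CC1`, gives 17 nM. Compound 2, `CCN(CCCCc1ccccc1)C1CCc2ccsc2CC1`, carries a longer link between the amine and the aromatic ring, and in this assay compound 2 gives 12 nM. For the measured compounds named here, the single change between these two is benzyl in place of phenyl on a saturated chain carbon, three bonds along the chain from an amine nitrogen, and the step it made was a 1.4-fold lower number from compound 1 to compound 2 (0.15 log units; within the scatter). Compound 3, `Brc1cc2c(s1)CCC(NCCCc1ccccc1)CC2`, has a different core, and in this assay compound 3 gives 41 nM; the difference between the core of compound 3 and the core of compound 1 is not broken down here, and compound 3 stands beyond the scatter from both of the other measured compounds.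

Compound 4, `Brc1cc2c(s1)CCC(NCCCCc1ccccc1)CC2`, is not yet measured. Going by the values given here, its relation to compound 3 is benzyl in place of phenyl on a saturated chain carbon, three bonds along the chain from an amine nitrogen, which is the same change as the one from compound 1 to compound 2. Since that earlier step stayed within the scatter, a similar, small step is expected from compound 3 to compound 4, namely a 1.4-fold lower number from compound 3 to compound 4 (0.14 log units; within the scatter). Accordingly, the value of compound 4 in this assay is estimated at 30 nM.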

Compound 4, inhibition constant: 14 nM
Compound 4: the middle estimate sits 2.1-fold (0.33 log units) above what was measured, and the stated range ends above it.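

In this assay, putting benzyl in place of phenyl on a saturated chain carbon, three bonds along the chain from an amine nitrogen, gives a 2.9-fold lower number from compound 3 to compound 4 (0.47 log units; beyond the scatter), a step that on its own lies beyond the usual scatter of repeat measurements. Both steps made by this change run in the same direction, and the gap between them is small enough that they can be treated as one effect of similar size on the two cores: the same change on two cores in this assay, a 1.4-fold lower number (0.15 log units; within the scatter) from compound 1 to compound 2 and a 2.9-fold lower number (0.47 log units; beyond the scatter) from compound 3 to compound 4, 2.1-fold (0.32 log units) apart, within the scatter of two such steps. For the compounds shown here, this supports carrying the change from the core of compound 1 to the core of compound 3 in this assay, but it rests on only two pairs of compounds, so it neither shows that the step would hold on any other core nor explains why it looks larger on the second core.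

The compounds shown leave open whether a still longer chain would lower the number further. They also leave open how the same change would behave with a methyl group or an acetyl group on the amine nitrogen.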